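Removing the methoxy group from compound 1

A few compounds are considered here, and "the series" means these few. Any claim that something is new, unique, unknown or untested is made for them only; others in the source may bear on it.

Compound 1 `COc1ccc(N=C2NC(=O)/C(=C\c3ccc(N(C)C)cc3)S2)cc1` gives only a limit in an ADME assay on cells (Homo sapiens) for antiproliferative activity; a higher number here means a weaker inhibitor, a lower number a stronger inhibitor: compound 1 stands at > 100000 nM. Compound 2 `O=C1N/C(=N\c2ccc(Cl)cc2)S/C1=C/c1ccccc1O` also gives a limit, > 100000 nM. Both results sit at one value: the limit of > 100000 nM in this assay, at which 2 of the 2 values shown sit. Compound 3 `CN(C)c1ccc(/C=C2/SC(=Nc3ccccc3)NC2=O)cc1` carries hydrogen in place of methoxy on an aromatic carbon, para to a large group (hydrogen in place of methoxy on an aromatic carbon). Within the data shown here, no measured step sizes this change, so no step beyond the scatter is expected in this assay, and the expected step is a number no higher from compound 1 to compound 3 (the limit leaves the size open). Compound 3 is expected at about 100000 nM, with an estimated range of 30000 nM to 200000 nM.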

Compound 3, half-maximal inhibitory concentration: > 100000 nM
Compound 3 ended at the assay's limit; the forecaster's own chance of this, stated with the estimate: 75%; the middle value lies on the limit itself.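

Compound 1 and compound 3 both give only a limit, so no step between them can be read in this assay: the limit of > 100000 nM in this assay, at which 3 of the 3 values shown sit.

The compounds shown leave open what the change from 4-methoxyphenyl to phenyl does to potency, and whether any close relative of these compounds gives a value inside the assay's range.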